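The source may report more compounds than this note shows. Statements on the series, on what has been measured and on what is new or still open speak of the compounds shown alone.

Compound 2 `O=C(Nc1ccc(Oc2ccnc3[nH]ccc23)c(F)c1)c1cc(-c2ccccc2)ncn1` gives the highest number of the two measured, 4640 nM in a functional assay on MCF7 cells (Homo sapiens) for cytotoxicity, read by MTT assay, with a stated time of 72 h; on this read-out higher numbers stand for weaker inhibition and lower numbers for stronger inhibition. Compound 1 `O=C(Nc1ccc(Oc2ccnc3[nH]ccc23)cc1)c1cc(-c2ccccc2)ncn1` gives 20 nM in this assay, and the step of a 230-fold higher number from compound 1 to compound 2 (2.37 log units; beyond the scatter) is large. Compound 3 `O=C(Nc1ccc(Oc2ccnc3[nH]ccc23)c(F)c1)c1cc(-c2ccc(F)cc2)ncn1` differs from compound 2 by fluoro in place of hydrogen on an aromatic carbon, para to a large group. For the measured compounds named here, the only measured step placed its fluoro on a different ring of the shared core, so it bears on this change only loosely. For compound 3 a change within or near the scatter is expected, a 1.1-fold higher number from compound 2 to compound 3 (0.03 log units; within the scatter). The number for compound 3 is estimated at 5000 nM, between 1500 nM and 16000 nM.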

Compound 3, half-maximal inhibitory concentration: "not active" (no number reported)
Nothing numeric was reported for compound 3; the estimate stays without a comparison.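

For the compounds shown here, compound 3 is reported as "not active" without a number, so no step from compound 2 to compound 3 can be read. No evidence bears on this result. Going by these compounds, how far phenyl to 4-fluorophenyl moves the number in this assay remains open.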